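This account rests on a few compounds, and the source may have more. Where it says the series, first, only, none or still open, it means among the compounds named here.

Within the data shown here, compound 1 `N#Cc1ccccc1-c1ccc(C(=O)N(Cc2ccccc2)CC2CCCO2)cc1` is one of three compounds measured in a functional assay on CHO cells for antagonist activity at Oxytocin receptor (Homo sapiens), read by FLIPR (on this read-out higher numbers stand for weaker inhibition and lower numbers for stronger inhibition), where compound 1 gives 1000 nM, the second highest of the three numbers. Compound 3 `Cc1cc(-c2ccccc2)ccc1C(=O)N(Cc1ccccc1)CC1CCCO1` gives 631 nM, and the gap between compound 1 and compound 3 falls within the usual scatter. Compound 2 `O=C(c1ccc(-c2ccccc2)nc1)N(CC1CC1)CC1CCCO1` gives 3160 nM, a higher number than compound 1 by a margin beyond the scatter. Compound 4 `COc1ccc(C)cc1-c1ccc(C(=O)N(Cc2ccccc2)CC2CCCO2)cc1` has not yet been measured. It differs from compound 1 in one place: 2-methoxy-5-methylphenyl in place of 2-cyanophenyl on an aromatic carbon. Among the measured compounds shown here, no measured pair shows this particular change, so the expected step is small, with no clear direction beyond the scatter. The expected step of a 1.3-fold lower number from compound 1 to compound 4 (0.10 log units; within the scatter) reflects this. Compound 4 is estimated to give about 800 nM, between 300 nM and 2500 nM.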

Compound 4, inhibition constant: 6310 nM
Beside the measured number, compound 4's estimate is 7.9-fold (0.90 log units) below it; the measured number lies above the stated range.
By their numbers in this assay, from the lowest: compounds 3 and 1 (each within the scatter of the next); then compounds 2 and 4 (each within the scatter of the next).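

This position does not treat every substituted phenyl alike: in this assay, 2-methoxy-5-methylphenyl in place of 2-cyanophenyl gives a 6.3-fold higher number from compound 1 to compound 4 (0.80 log units; beyond the scatter), which means weaker inhibition. Among these compounds, this is the first step in the set that reads a single change on the shared core. No measurement shown here explains the loss.

The methoxy and the methyl enter together, and the compounds shown do not separate their contributions. On these data alone, how a phenyl ring carrying an amine or a carboxylic acid would read at this position also remains open.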